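Dimethoxyphenyl swap on the lower-number compound

This account rests on a few compounds, and the source may have more. Where it says the series, first, only, none or still open, it means among the compounds named here.

Values in a functional assay on A549 cells (Homo sapiens) for antiproliferative activity, read by sulforhodamine B assay, with a stated time of 48 h (on this read-out higher numbers stand for weaker inhibition and lower numbers for stronger inhibition), for the two measured compounds:
- compound 1 `COc1ccc(OC)c(/C=C/C(=O)/C=C(O)/C=C/c2cc(OC)ccc2OC)c1` gives 16300 nM
- compound 2 `COc1ccc(C=C(C(=O)/C=C/c2cccc(OC)c2OC)C(=O)/C=C/c2cccc(OC)c2OC)cc1OC` gives 170 nM

Compound 2 holds the lower of the two numbers at 170 nM, while compound 1 gives 16300 nM on this read-out. The gap between these two values lies beyond the scatter. Compound 3 `COc1cccc(C=C(C(=O)/C=C/c2cccc(OC)c2OC)C(=O)/C=C/c2cccc(OC)c2OC)c1OC` is the next case, with one change from compound 2 (2,3-dimethoxyphenyl in place of 3,4-dimethoxyphenyl on a double-bonded chain carbon bound to a double-bonded chain carbon) that places 2,3-dimethoxyphenyl in place of 3,4-dimethoxyphenyl on a double-bonded chain carbon bound to a double-bonded chain carbon. Going by the values given here, no measured pair isolates this change in this assay so the expectation rests on compound 2 at 170 nM and on the same atom count in both groups. The expected change (a 1.8-fold higher number from compound 2 to compound 3 (0.25 log units; within the scatter)) is toward a somewhat higher number and no larger than the scatter. For compound 3 the estimated value is 300 nM with an expected range of 90 nM to 1200 nM in this assay's terms.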

Compound 3, half-maximal inhibitory concentration: 320 nM
Estimate against measurement, compound 3: 1.1-fold (0.03 log units) below; measured number inside the range.
By their numbers in this assay, from the lowest: compounds 2 and 3 (each within the scatter of the next); then compound 1.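

In this assay, going by these compounds alone, the step of a 1.9-fold higher number from compound 2 to compound 3 (0.27 log units; within the scatter) is the first reading on this position, where 2,3-dimethoxyphenyl takes the place of 3,4-dimethoxyphenyl on a double-bonded chain carbon bound to a double-bonded chain carbon. It shows that the two dimethoxyphenyl arrangements cannot be told apart at this place, so the rearrangement of the two methoxy groups leaves compound 2 and compound 3 reading alike on this assay. Nothing on hand accounts for this outcome. As far as these compounds go, whether this position accepts a group other than a dimethoxyphenyl remains open, for example a plain phenyl, a hydroxyphenyl or a dimethylaminophenyl. Within the data shown here, also open is whether the same equivalence carries over to a core other than the one shared by compound 2 and compound 3.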